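Lengthening an Ether Chain on the Shared Core

This account rests on a few compounds, and the source may have more. Where it says the series, first, only, none or still open, it means among the compounds named here.

Of the compounds shown here, three have been measured in a functional assay on SMMC-7721 cells (Homo sapiens) for cytotoxicity, read by MTT assay, with a stated time of 72 h; on this read-out lower numbers stand for stronger inhibition and higher numbers for weaker inhibition. Compound 2 `COCNc1n[n+]([O-])c2ccccc2[n+]1[O-]` gives 6670 nM, the lowest of the three numbers, although compound 1 `COc1ccc2c(c1)[n+]([O-])nc(NCOC(C)c1ccccc1)[n+]2[O-]` with 8040 nM lies within the scatter of it; compound 3 `COc1ccc2c(c1)[n+]([O-])nc(NCOCc1ccccc1)[n+]2[O-]` gives 21400 nM, beyond the scatter. Compound 4 `CCCOCNc1n[n+]([O-])c2ccccc2[n+]1[O-]` differs from compound 2 by one change: ethyl in place of hydrogen on a saturated chain carbon bound to an oxygen on a saturated carbon. Among the measured compounds shown here, only one measured step resembles it, the removal of a methyl from a chain carbon, where a 2.7-fold higher number from compound 1 to compound 3 (0.43 log units; beyond the scatter), so carbon added at a chain carbon went with a lower number. That carbon sat at a different place, so the guidance is loose. A modest lowering of the number is expected, a 1.5-fold lower number from compound 2 to compound 4 (0.17 log units; within the scatter), in this assay. Compound 4 is expected to give about 4500 nM, between 2000 nM and 10000 nM.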

Compound 4, half-maximal inhibitory concentration: 19500 nM
Estimate against measurement, compound 4: 4.3-fold (0.64 log units) below; the whole stated range lies below it.
By their numbers in this assay, from the lowest: compounds 2 and 1 (each within the scatter of the next); then compounds 4 and 3 (each within the scatter of the next).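

In this assay, replacing methoxy with propoxy on the shared core brings a 2.9-fold higher number from compound 2 to compound 4 (0.47 log units; beyond the scatter), so added carbon on this chain raises the number. The earlier step, a 2.7-fold higher number from compound 1 to compound 3 (0.43 log units; beyond the scatter), came from losing a methyl at a different chain carbon, which means that added carbon there went with a lower number, and the two places do not behave alike. Nothing measured here explains the rise. Methoxy and propoxy alone fix no trend with chain length, so where an ethoxy or a butoxy chain would fall remains open.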